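A few compounds are considered here, and "the series" means these few. Any claim that something is new, unique, unknown or untested is made for them only; others in the source may bear on it.

Measured compounds in an ADME assay on MT4 cells (Homo sapiens) for cytotoxicity, read by MTT assay, with a stated time of 5 days; a lower number here means that less compound is tolerated, a higher number that more compound is tolerated:
Compound 1, `Cc1cc(/C=C/C#N)cc(C)c1Oc1nc(Nc2ccc(N3CCCC(NS(N)(=O)=O)C3)cc2)nc2ccsc12`: a limit of the assay only, > 217000 nM.
Compound 2, `Cc1cc(/C=C/C#N)cc(C)c1Oc1nc(Nc2ccc(CN3CCNCC3)cc2)nc2ccsc12`: 3970 nM.
Compound 3, `Cc1cc(/C=C/C#N)cc(C)c1Oc1nc(Nc2ccc(N3CCCC(N)C3)cc2)nc2ccsc12`: 3820 nM.

Compound 3 stands at the lowest of the two numbers, with compound 2 within the scatter of it, as a 1.0-fold lower number from compound 2 to compound 3 (0.02 log units; within the scatter) shows; the third value is a limit. Compound 4, `Cc1cc(/C=C/C#N)cc(C)c1Oc1nc(Nc2ccc(N3CCN(S(N)(=O)=O)CC3)cc2)nc2ccsc12`, differs from compound 3 by 4-sulfamoylpiperazin-1-yl in place of 3-aminopiperidin-1-yl on an aromatic carbon. Within the data shown here, the measured step that bears on this change is the one between compound 1 and compound 3, an at least 56-fold lower number from compound 1 to compound 3 (1.75 log units; beyond the scatter), where hydrogen replaced sulfamoyl on an amine nitrogen. Compound 4 reverses that change, putting a sulfamoyl back onto a ring nitrogen. The step of an at least 54-fold lower number from compound 1 to compound 2 (1.73 log units; beyond the scatter) points the same way. A large rise in this assay is therefore expected for compound 4, a 39-fold higher number from compound 3 to compound 4 (1.59 log units; beyond the scatter), quite possibly ending again at the limit of > 217000 nM in this assay, at which 1 of the 3 values shown sits. Compound 4 is estimated at 150000 nM, with a range from 30000 nM to 300000 nM.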

Compound 4, half-maximal cytotoxic concentration: > 222000 nM
Compound 4: a limit, no number; the forecaster's own chance of this, stated with the estimate: 55%; at least 1.4-fold (0.17 log units) between middle value and limit.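

In this assay, sulfamoyl now sits on a ring nitrogen, in 4-sulfamoylpiperazin-1-yl, rather than on the side-chain amine of compound 1, and both readable steps are large and beyond the scatter: an at least 58-fold higher number from compound 3 to compound 4 (1.76 log units; beyond the scatter) and an at least 55-fold higher number from compound 2 to compound 4 (1.74 log units; beyond the scatter) both point upward. The value of compound 4, > 222000 nM, is a limit of the assay and not a number. Compound 1 and compound 4 both stand as limits, so the step between them cannot be read and the two sulfamoyl-bearing groups cannot be ordered.

Open, on these data alone, is how a piperazin-1-yl with a free ring nitrogen would stand on the same aromatic carbon, which would separate the sulfamoyl from the ring change. Also open, as far as these compounds go, is whether an acetyl or a methanesulfonyl group on that nitrogen would give a similar rise.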